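Swapping the Sulfonyl Substituent in a Nicotinamide Phosphoribosyltransferase Series

The compounds below may be only part of what the source reports. "The series", "measured", "known", "first", "only" and "open" are said of these compounds alone.

Three compounds share one core and differ only in the group carried on a sulfonyl sulfur. Compound 1 `CCCn1cc(S(=O)(=O)c2ccc(CNC(=O)N3Cc4ccncc4C3)cc2)cn1` bears a 1-propyl-1H-pyrazol-4-yl group there, compound 2 `O=C(NCc1ccc(S(=O)(=O)C2CCC(F)(F)CC2)cc1)N1Cc2ccncc2C1` a 4,4-difluorocyclohexyl group, and compound 3 `CCC(=O)N1CCC(S(=O)(=O)c2ccc(CNC(=O)N3Cc4ccncc4C3)cc2)CC1` a 1-propanoylpiperidin-4-yl group. In an assay on isolated protein for inhibition of Nicotinamide phosphoribosyltransferase (Homo sapiens), read by mass spectrometry, with stated times of 15 min and 30 min (on this read-out higher numbers stand for weaker inhibition and lower numbers for stronger inhibition), compound 1 gives 17 nM, compound 2 gives 78 nM, and compound 3 gives 27 nM. Compound 3 therefore holds the second highest of the three numbers: its value and that of compound 1 lie within the usual scatter, while the step of a 2.9-fold lower number from compound 2 to compound 3 (0.46 log units; beyond the scatter) lies beyond it.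

Compound 4 `O=C(NCc1ccc(S(=O)(=O)N2CCC[C@@H](O)C2)cc1)N1Cc2ccncc2C1` is the next variation at the same place: 3-hydroxypiperidin-1-yl in place of 1-propanoylpiperidin-4-yl on a sulfonyl sulfur. Within the data shown here, the steps that bear on this change are the earlier swaps at the sulfonyl sulfur, namely a 4.6-fold higher number from compound 1 to compound 2 (0.66 log units; beyond the scatter), a 1.6-fold higher number from compound 1 to compound 3 (0.20 log units; within the scatter) and a 2.9-fold lower number from compound 2 to compound 3 (0.46 log units; beyond the scatter). Among the measured compounds shown here, all three changed the number by modest amounts at most, and the present change again replaces only that group. For the measured compounds named here, a modest rise in the number is expected for compound 4, a 2.2-fold higher number from compound 3 to compound 4 (0.35 log units; beyond the scatter), since the new group is joined through nitrogen and adds a hydrogen-bond donor that none of the measured groups carried. Compound 4 is therefore estimated at 60 nM, with a likely range from 20 nM to 180 nM.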

Compound 4, half-maximal inhibitory concentration: 28 nM
The estimate for compound 4 lay 2.1-fold (0.33 log units) above the measured number, within the range that was stated.
By their numbers in this assay, from the lowest: compounds 1, 3 and 4 (each within the scatter of the next); then compound 2.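

Joining the group through nitrogen, as the 3-hydroxypiperidin-1-yl group of compound 4 is joined, leaves the number in this assay in step with the carbon-joined 1-propanoylpiperidin-4-yl group (a 1.0-fold higher number from compound 3 to compound 4 (0.02 log units; within the scatter)), even though the entering group has fewer heavy atoms and brings a hydrogen-bond donor that the leaving group lacks. So this place on the sulfonyl sulfur has now taken three quite different groups with no separation beyond the scatter, as the comparison with the pyrazole-bearing compound also shows (a 1.6-fold higher number from compound 1 to compound 4 (0.22 log units; within the scatter)), while compound 2 with its 4,4-difluorocyclohexyl group remains the one compound set apart (a 2.8-fold lower number from compound 2 to compound 4 (0.44 log units; beyond the scatter)). No measurement available here explains why these different groups give such similar numbers.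

The compounds shown do not separate the contribution of the hydroxyl from that of the ring joined through nitrogen, and a plain piperidin-1-yl group or the mirror-image form of the 3-hydroxypiperidin-1-yl group would speak to that. They also leave open how this place would respond to a carboxylic acid or a free amine carried on the same ring.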